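Swapping anilino for phenoxy in a hydrazone series

This account rests on a few compounds, and the source may have more. Where it says the series, first, only, none or still open, it means among the compounds named here.

Compound 1 `CC(/C=N/Nc1ccc([N+](=O)[O-])cc1)=N\NC(=O)c1ccccc1Nc1ccccc1` was tested in an ADME assay on J774 cells (Mus musculus, strain BALB/c) for cytotoxicity, read by resazurin assay, with a stated time of 72 h (a higher number here means that more compound is tolerated, a lower number that less compound is tolerated), where the read-out is the half-maximal cytotoxic concentration. In this assay compound 1 reaches only the limit of the assay, > 100000 nM, so no exact number is known for it. Two related compounds do give numbers: compound 2 `CC(/C=N/N(C)c1ccc([N+](=O)[O-])cc1)=N\NC(=O)c1ccccc1O` shows 31500 nM in this assay, and compound 3 `CC(/C=N/Nc1ccc([N+](=O)[O-])cc1)=N\NC(=O)c1ccc(C(F)(F)F)cc1` shows 78700 nM. Compound 1 stands at the limit of > 100000 nM in this assay, at which 1 of the 3 values shown sits. Among the compounds with values here, no step between measured compounds that differ in a single place is available, so the size of any change can only be expected, not read off.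

The new compound 4 `CC(/C=N/Nc1ccc([N+](=O)[O-])cc1)=N\NC(=O)c1ccccc1Oc1ccccc1` differs from compound 1 by phenoxy in place of anilino on an aromatic carbon. Given that the measured compounds all fall in a range of high tolerance, the expected step is an at least 1.4-fold lower number from compound 1 to compound 4 (0.15 log units; that floor lies within the scatter), leaning toward somewhat less tolerance but not clearly beyond the usual scatter. Compound 4 is therefore estimated at 70000 nM, within 25000 nM to 150000 nM.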

Compound 4, half-maximal cytotoxic concentration: > 100000 nM
Compound 4: only a limit was reported (the forecaster's own chance of this, stated with the estimate: 40%); at least 1.4-fold (0.15 log units) between middle value and limit.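

In this assay, within the data shown here, compound 1 and compound 4 each give only a limit and not a number, so no step between them can be read: the limit of > 100000 nM in this assay, at which 2 of the 4 values shown sit.

The compounds shown leave open whether phenoxy in place of anilino changes how much compound the cells tolerate, and by how much.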